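Cyclohexyl for methoxyphenyl on a ring amide nitrogen

The compounds below may be only part of what the source reports. "The series", "measured", "known", "first", "only" and "open" are said of these compounds alone.

Three compounds have been measured in a functional assay on HepG2 cells (Homo sapiens) for antiproliferative activity, read by MTT assay, with a stated time of 72 h; a higher number here means a weaker inhibitor, a lower number a stronger inhibitor:

Compound 1 `COc1cccc(N2C(=O)COc3ccc(-c4cnc(Cl)c(NS(=O)(=O)c5ccc(F)cc5)c4)cc32)c1` gives > 40000 nM, which is a limit of the assay and not a number.
Compound 2 `O=C1COc2ccc(-c3cnc(Cl)c(NS(=O)(=O)c4ccc(F)cc4)c3)cc2N1C1CCCCC1` gives > 40000 nM, again a limit rather than a number.
Compound 3 `COc1cccc(N2C(=O)COc3ccc(-c4cnc5ccccc5c4)cc32)c1` gives 2080 nM.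

Compound 1 and compound 2 share one core and differ only by cyclohexyl in place of 3-methoxyphenyl on an amide-type nitrogen in a ring. Because both of them sit at the limit of > 40000 nM in this assay, at which 2 of the 3 values shown sit, the step that the two limits leave unreadable from compound 1 to compound 2 cannot be read, so this pair says nothing about how large the change is.

Compound 3 carries a different core from compound 1; how the two cores differ is not broken down here. Compound 3 is the only one of the three with a real number in this assay.

Compound 4 `O=C1COc2ccc(-c3cnc4ccccc4c3)cc2N1C1CCCCC1` has not yet been measured. It differs from compound 3 by cyclohexyl in place of 3-methoxyphenyl on an amide-type nitrogen in a ring, the same change as that from compound 1 to compound 2, at the same place in the ring.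

Going by the values given here, since the only measured instance of this change is unreadable, there is no measured step to lean on. The expectation for compound 4 therefore rests on compound 3 alone, with its value of 2080 nM, and the step from compound 3 to compound 4 is expected to be about a 1.4-fold higher number from compound 3 to compound 4 (0.16 log units; within the scatter). Compound 4 is estimated at 3000 nM, with a range from 800 nM to 15000 nM expected.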

Compound 4, half-maximal inhibitory concentration: > 40000 nM
Compound 4: a limit, no number (the forecaster's own chance of this, stated with the estimate: 12%); middle value at least 13-fold (1.12 log units) away from the limit.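

In this assay, putting cyclohexyl in place of 3-methoxyphenyl on the amide-type nitrogen in a ring gives an at least 19-fold higher number from compound 3 to compound 4 (1.28 log units; beyond the scatter), so on the core of compound 3 this change produces a clearly weaker inhibitor. As far as these compounds go, compound 4 gives > 40000 nM, which is a limit and not a number, so the real size of the step remains unknown and may be larger than printed. Going by these compounds alone, the same change from compound 1 to compound 2 cannot be read, which leaves this as the only readable instance, and it therefore does not show whether the loss carries from one core to another; most of the series gives no numbers to compare: the limit of > 40000 nM in this assay, at which 3 of the 4 values shown sit.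

The compounds shown leave open whether the loss follows from removing the aromatic ring or from removing the methoxy group, a question that a plain phenyl on the same nitrogen of the core of compound 3 could help to settle. They also leave open how a small methyl group, or a cyclohexyl carrying an amine, would read on that nitrogen.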